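The compounds below may be only part of what the source reports. "The series", "measured", "known", "first", "only" and "open" are said of these compounds alone.

Measured compounds in a functional assay on HepG2 cells for inhibition of squalene monooxygenase (Homo sapiens); on this read-out lower numbers stand for stronger inhibition and higher numbers for weaker inhibition:

Compound 1, `CCN(C/C=C/C#CC(C)(C)C)Cc1cccc(OCCN(C)S(=O)(=O)c2cccs2)c1`: 60 nM
Compound 2, `CCN(C/C=C/C#CC(C)(C)C)Cc1cccc(OCCN(C)S(=O)(=O)c2ccc(F)cc2)c1`: 255 nM
Compound 3, `CCN(C/C=C/C#CC(C)(C)C)Cc1cccc(OCCN(C)S(=O)(=O)c2ccc(Br)cc2)c1`: 330 nM

Compound 3 carries the highest number of the three. Its nearest neighbour is compound 2, and the step of a 1.3-fold higher number from compound 2 to compound 3 (0.11 log units; within the scatter) lies within the scatter, so the two cannot be placed in order. The step of a 5.5-fold higher number from compound 1 to compound 3 (0.74 log units; beyond the scatter) lies beyond the scatter, as does a 4.3-fold higher number from compound 1 to compound 2 (0.63 log units; beyond the scatter); both of those steps replace the thiophen-2-yl ring on the sulfonyl sulfur with a substituted phenyl ring, which is not the change at hand.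

Compound 4, `CCN(C/C=C/C#CC(C)(C)C)Cc1cccc(OCCN(C)S(=O)(=O)c2ccc(C#N)cc2)c1`, differs from compound 3 in one place: cyano in place of bromo on an aromatic carbon. Among the compounds with values here, the only measured step that touches the same position is a 1.3-fold higher number from compound 2 to compound 3 (0.11 log units; within the scatter), an exchange of one substituent for another on that aromatic carbon, and it stayed within the scatter. Within the data shown here, no measured step involves a cyano group, so the expectation rests on that single halogen exchange alone.

Compound 4 is therefore expected to give a number close to that of compound 3, with the estimated step of a 1.1-fold lower number from compound 3 to compound 4 (0.04 log units; within the scatter) not beyond the scatter. The estimate for compound 4 in this assay is 300 nM, within a range from 120 nM to 750 nM.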

Compound 4, half-maximal inhibitory concentration: 200 nM
Compound 4: middle estimate off by 1.5-fold (0.18 log units), on the high side; measured number inside the range.
By their numbers in this assay, from the lowest: compound 1; then compounds 4, 2 and 3 (each within the scatter of the next).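

In this assay, within the data shown here, the position para to a large group now holds a cyano group as well as the two halogens, and the change from a halogen to this group, with its triple bond, gives no step that can be told from scatter: the data show a 1.7-fold lower number from compound 3 to compound 4 (0.22 log units; within the scatter) and a 1.3-fold lower number from compound 2 to compound 4 (0.11 log units; within the scatter) and both stay within it. Compounds 2, 3 and 4 therefore cannot be placed in order, so the set of substituents tolerated at this position without a readable change extends beyond halogens. The gap to the thiophen-2-yl ring also holds for this third substituted phenyl ring, with a 3.3-fold higher number from compound 1 to compound 4 (0.52 log units; beyond the scatter) beyond the scatter, and no measurement available here bears on the reason for either finding.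

As far as these compounds go, what remains open is whether an unsubstituted phenyl ring would sit with compounds 2, 3 and 4 or nearer compound 1, and so whether the gap belongs to the ring or to its substituent. From the compounds shown here alone, it is also open whether a carboxylic acid, an amine or a methoxy group at the same position would give a step beyond the scatter.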